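The compounds below may be only part of what the source reports. "The series", "measured", "known", "first", "only" and "open" are said of these compounds alone.

Measured so far:
compound 1 `O=C1C=CC2(C=C1)OCC(=O)N2c1nc(-c2ccc3ncccc3c2)nn1-c1ccccc1`: 170 nM
compound 2 `O=C1C=CC2(C=C1)OCC(=O)N2c1nc(-c2ccc3ccccc3c2)nn1-c1ccccc1`: 140 nM

Both values come from a functional assay on A549 cells (Homo sapiens) for antiproliferative activity, with a stated time of 5 days; a higher number here means a weaker inhibitor, a lower number a stronger inhibitor. Compound 2, at 140 nM, stands within the scatter of compound 1, so the two cannot be ranked. The next compound to be tested is compound 3 `O=C1C=CC2(C=C1)OCC(=O)N2c1nc(-c2cccc(Cl)c2)nn1-c1ccccc1`, which carries 3-chlorophenyl in place of naphthalen-2-yl on an aromatic carbon of the five-membered aromatic ring with 3 nitrogen. The difference is 3-chlorophenyl in place of naphthalen-2-yl on an aromatic carbon.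

Among the measured compounds shown here, only one measured step bears on this place: a 1.2-fold lower number from compound 1 to compound 2 (0.08 log units; within the scatter), with naphthalen-2-yl in place of quinolin-6-yl. That step shows that one of these two groups can stand in for the other without a measurable change in this assay. For the measured compounds named here, it is only a weak guide, however, since no measured compound has a single ring at this carbon. A modest move to a higher number is therefore expected, though it may not clear the scatter. The expected change is a 2.1-fold higher number from compound 2 to compound 3 (0.33 log units; beyond the scatter). For compound 3 the estimated value is 300 nM, with an expected range of 100 nM to 900 nM.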

Compound 3, half-maximal inhibitory concentration: 25.2 nM
Compound 3: middle estimate off by 12-fold (1.08 log units), on the high side; measured number outside the range, below it.
By their numbers in this assay, from the lowest: compound 3; then compounds 2 and 1 (each within the scatter of the next).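

In this assay, among the compounds shown here, the carbon between two ring nitrogen atoms now proves sensitive to the group it carries, whereas the only earlier step there, a 1.2-fold lower number from compound 1 to compound 2 (0.08 log units; within the scatter), gave no measurable change. Replacing naphthalen-2-yl with 3-chlorophenyl gives a 5.6-fold lower number from compound 2 to compound 3 (0.74 log units; beyond the scatter), and replacing quinolin-6-yl with the same group gives a 6.7-fold lower number from compound 1 to compound 3 (0.83 log units; beyond the scatter), so among these three compounds the single chlorinated ring gives a lower number than either group with two rings, and none of the three goes against this. No evidence is available to explain this difference.

These compounds cannot show whether the lower number in compound 3 belongs to the chlorine atom, to the change from two rings to one, or to both together, since that step alters all of these at once. An unsubstituted phenyl at this carbon would separate these contributions, while a phenyl ring carrying a methoxy group or an amine in place of the chlorine would show how far the result depends on chlorine itself.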